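This account rests on a few compounds, and the source may have more. Where it says the series, first, only, none or still open, it means among the compounds named here.

Three compounds have been measured in a functional assay on A549 cells (Homo sapiens) for antiproliferative activity, read by MTT assay, with a stated time of 72 h; a higher number here means a weaker inhibitor, a lower number a stronger inhibitor:
- compound 1 `CCN(CC)C(=N)NC(=N)Nc1ccc(F)c(F)c1` gives 7800 nM
- compound 2 `CC(C)CNC(=N)NC(=N)Nc1ccc(F)cc1F` gives 3600 nM
- compound 3 `CCN(CC)C(=N)NC(=N)Nc1ccc(C(F)(F)F)cc1` gives 3700 nM

Compound 2 has the lowest of these three numbers. Its gap to compound 3 lies within the usual scatter of repeated measurements, so those two cannot be put in order. Its gap to compound 1 lies beyond the scatter, so compound 2 is the stronger inhibitor of that pair. Compound 4 `N=C(NC(=N)NC1CCCC1)Nc1ccc(F)cc1F` has not yet been measured. It differs from compound 2 in one respect: cyclopentyl in place of isobutyl on an amine nitrogen. Among the measured compounds shown here, no measured pair shows what such a change does in this assay, so the step from compound 2 to compound 4 is expected to be small, with no clear direction beyond the scatter, a 1.1-fold lower number from compound 2 to compound 4 (0.05 log units; within the scatter). Compound 4 is therefore estimated at 3200 nM, within a range from 1300 nM to 8000 nM.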

Compound 4, half-maximal inhibitory concentration: 4000 nM
Compound 4: the middle estimate sits 1.3-fold (0.10 log units) below what was measured, within the range that was stated.
By their numbers in this assay, from the lowest: compounds 2, 3, 4 and 1 (each within the scatter of the next, the first and the last beyond it).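

In this assay, placing cyclopentyl instead of isobutyl on this amine nitrogen gives a 1.1-fold higher number from compound 2 to compound 4 (0.05 log units; within the scatter) and so leaves the number unchanged within the scatter. At this position, then, closing the carbon group into a five-membered ring and adding one carbon does not separate the two compounds in this read-out. No measurement here offers an explanation for this result. The compounds shown leave open whether a larger group at this nitrogen, such as cyclohexyl or benzyl, would move the number beyond the scatter. Going by these compounds, a carboxylic acid on the chain also remains untested here.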